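From compound 2 to compound 4: an amino group enters

A few compounds are considered here, and "the series" means these few. Any claim that something is new, unique, unknown or untested is made for them only; others in the source may bear on it.

compound 1 `O=C(Nc1cccc(-n2cc(-c3ccncc3)c(-c3ccc(Cl)c(O)c3)n2)c1)Nc1cccc(C(F)(F)F)c1` at > 32500 nM
compound 2 `COc1cc(-c2nn(-c3cccc(NC(=O)c4cccc(C(F)(F)F)c4)c3)cc2-c2ccncc2)ccc1Cl` at > 50000 nM
compound 3 `O=C(Nc1cccc(-n2cc(-c3ccncc3)c(-c3ccc(Cl)c(O)c3)n2)c1)Nc1ccc(Cl)c(Cl)c1` at > 32500 nM

Each of these results from a functional assay on NCI-H226 cells (Homo sapiens) for inhibition, read by sulforhodamine B assay, with a stated time of 48 h (on this read-out higher numbers stand for lower toxicity in this test and lower numbers for higher toxicity in this test), is a limit of the assay and not a number. Compound 2 has the limit > 50000 nM and no measured number. Compound 4 `COc1cc(-c2nn(-c3cccc(NC(=O)Nc4cccc(C(F)(F)F)c4)c3)cc2-c2ccncc2)ccc1Cl` is still unmeasured and departs from compound 2 in one place, on a carbonyl carbon, by this change: (3-(trifluoromethyl)phenyl)amino in place of 3-(trifluoromethyl)phenyl on a carbonyl carbon and nothing else. Going by the values given here, the one measured step is a step that the two limits leave unreadable from compound 1 to compound 3 and it concerns another group, so it offers no size to carry over. Compound 1 already carries the (3-(trifluoromethyl)phenyl)amino group, and the limit of compound 1 is > 32500 nM in this assay as well. No step beyond the scatter is therefore expected in this assay in either direction. The expected step is an at least 1.2-fold lower number from compound 2 to compound 4 (0.09 log units; that floor lies within the scatter) and it is an estimate only. For compound 4 the estimated value is 40000 nM with an expected range from 15000 nM to 80000 nM and the assay may again report only a limit.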

Compound 4, concentration lethal to 50% of the cells: > 50000 nM
Compound 4 ended at the assay's limit; the forecaster's own chance of this, stated with the estimate: 70%; middle value at least 1.2-fold (0.09 log units) away from the limit.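

In this assay, compound 4 gives only a limit, as do compound 1 and compound 2, so neither step to compound 4 can be read. The compounds shown leave open whether (3-(trifluoromethyl)phenyl)amino in place of 3-(trifluoromethyl)phenyl, or methyl in place of hydrogen on the oxygen, changes the result in this assay at all.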